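The source may hold more compounds than are shown below. What is called first, only, known or untested is meant among the compounds shown, and "the series" means these compounds.

Measured compounds in a functional assay on MOLT-4 cells (Homo sapiens) for inhibition, read by MTT assay, with a stated time of 72 h; a lower number here means a stronger inhibitor, a higher number a weaker inhibitor:
- compound 1 `COc1cc(NC(C)CCCNC(=O)Nc2cccc(Cl)c2)c2ncccc2c1` gives 21000 nM
- compound 2 `COc1cc(NC(C)CCCNC(=O)Nc2ccc(Br)cc2)c2ncccc2c1` gives 25000 nM
- compound 3 `COc1cc(NC(C)CCCNC(=O)NNC(=O)Nc2ccc(Cl)cc2)c2ncccc2c1` gives 186000 nM

Compound 3 stands at the highest number of the three in this assay; its nearest neighbour is compound 2 and its furthest is compound 1, both separated from it by steps beyond the scatter: a 7.4-fold higher number from compound 2 to compound 3 (0.87 log units; beyond the scatter) and an 8.9-fold higher number from compound 1 to compound 3 (0.95 log units; beyond the scatter). Both of those steps insert the ((4-chlorophenyl)carbamoyl)amino unit onto the amide-type nitrogen, and both lie in the same direction and of similar size.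

Compound 4 `COc1cc(NC(C)CCCNC(=O)NNC(=O)Nc2cccc(Cl)c2)c2ncccc2c1` keeps that inserted unit and differs from compound 3 only in the aryl group it carries: 3-chlorophenyl in place of 4-chlorophenyl on an amide-type nitrogen. For the measured compounds named here, the one measured step that bears on moving the halogen around the ring is a 1.2-fold higher number from compound 1 to compound 2 (0.08 log units; within the scatter), which falls within the scatter. Going by the values given here, no measured pair shows a 3-chlorophenyl against a 4-chlorophenyl directly. On this basis no step beyond the scatter is expected in this assay from compound 3 to compound 4, and the expected change is a 1.0-fold lower number from compound 3 to compound 4 (0.01 log units; within the scatter). Compound 4 is therefore estimated at 180000 nM, with a range from 80000 nM to 400000 nM.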

Compound 4, half-maximal inhibitory concentration: 93000 nM
Estimate against measurement, compound 4: 1.9-fold (0.29 log units) above; low and high end bracket the measured number.
By their numbers in this assay, from the lowest: compounds 1 and 2 (each within the scatter of the next); then compounds 4 and 3 (each within the scatter of the next).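

In this assay, for the compounds shown here, the first direct comparison of 3-chlorophenyl with 4-chlorophenyl on this amide-type nitrogen, made with the carbamoyl-bearing unit in place, does not separate the two groups, with the step within the scatter (a 2.0-fold lower number from compound 3 to compound 4 (0.30 log units; within the scatter)). Going by these compounds alone, compound 4 also gives the first comparison in which the aryl group stays 3-chlorophenyl and only the ((3-chlorophenyl)carbamoyl)amino unit replaces the directly attached aryl group, and the number rises beyond the scatter (a 4.4-fold higher number from compound 1 to compound 4 (0.65 log units; beyond the scatter)); the rise against the 4-bromophenyl member, where the aryl group changes as well, is likewise beyond the scatter (a 3.7-fold higher number from compound 2 to compound 4 (0.57 log units; beyond the scatter)). The data at hand offer no explanation for either the shift with the inserted unit or the lack of separation between the two chlorophenyl groups.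

Still open is whether the two chlorine placements also match without the inserted unit, as no 4-chlorophenyl partner of compound 1 is among the compounds shown. On these data alone, it is also open whether the rise follows the inserted unit when the aryl group is an unsubstituted phenyl or carries a carboxylic acid, and whether a longer chain to the core changes the picture.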